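Removing the Amino Group from Compound 1

This account rests on a few compounds, and the source may have more. Where it says the series, first, only, none or still open, it means among the compounds named here.

Among the measured compounds shown here, compound 1 `COc1nc(N)nc2c1c(-c1cc3ccccc3o1)cn2[C@@H]1O[C@H](CO)[C@@H](O)[C@H]1O` is the only member of this small set to give a number in a functional assay on CCRF-CEM cells (Homo sapiens), read by MTT assay, with a stated time of 72 h; on this read-out lower numbers stand for stronger inhibition and higher numbers for weaker inhibition: compound 1 gives 12700 nM. Compound 2 `Nc1nc2c(c(-c3ccccc3)cn2[C@@H]2O[C@H](CO)[C@@H](O)[C@H]2O)c(=O)[nH]1` is reported only as a limit of the assay, and in this assay compound 2 gives > 100000 nM. Compound 3 `COc1nc(N)nc2c1c(-c1ccccc1)cn2[C@@H]1O[C@H](CO)[C@@H](O)[C@H]1O` is likewise reported only as a limit, and in this assay compound 3 gives > 20000 nM. For the measured compounds named here, the one measured step, an at least 1.5-fold higher number from compound 1 to compound 3 (0.19 log units; that floor lies within the scatter), swaps the ring attached to the core and reaches only a floor that sits within the usual scatter, so it says little about direction or size.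

Compound 4 `COc1ncnc2c1c(-c1cc3ccccc3o1)cn2[C@@H]1O[C@H](CO)[C@@H](O)[C@H]1O` differs from compound 1 at another place on the core: hydrogen in place of amino on an aromatic carbon. Going by the values given here, no measured pair in this set changes the amino group, so none of the measured steps bears on this change, and the ring swap from compound 1 to compound 3 is not a guide for it. Without such evidence, no step beyond the scatter is expected in either direction in this assay, only a wide uncertainty. The expected step is a 1.2-fold higher number from compound 1 to compound 4 (0.07 log units; within the scatter). Compound 4 is therefore estimated to give 15000 nM, with a range from 4000 nM to 60000 nM.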

Compound 4, half-maximal inhibitory concentration: 5370 nM
Estimate against measurement, compound 4: 2.8-fold (0.45 log units) above; measured number inside the range.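

In this assay, among the compounds shown here, the change gives a 2.4-fold lower number from compound 1 to compound 4 (0.37 log units; beyond the scatter), and this is the first step in the set that lies beyond the scatter, as well as the first to touch the carbon between two ring nitrogen atoms. It shows that the amino group at this place is not needed for activity in these cells, at least with 1-benzofuran-2-yl on the core, since the number falls modestly once hydrogen takes its place. The data shown give no measured property that would explain this step.

Compound 3, which carries phenyl in place of 1-benzofuran-2-yl, is reported only as a limit of the assay, at > 20000 nM. It therefore remains open whether hydrogen in place of amino would also lower the number with phenyl on the core, and, with only two groups shown at this carbon, where a methyl group, a chlorine atom or a methylamino group there would fall relative to amino and hydrogen.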